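The compounds below may be only part of what the source reports. "The series", "measured", "known", "first", "only" and "open" are said of these compounds alone.

Measured compounds: compound 1 `COc1cc2c(Nc3ccc(C#N)cc3)ncnc2cc1OCCCN(C)C`, compound 2 `COc1cc2c(Nc3ccc(C#N)cc3)ncnc2cc1OCCCN1CCC(O)CC1`, compound 3 `COc1cc2c(Nc3ccc(C#N)cc3)ncnc2cc1OCCCN1CCC(CO)CC1`.

In a functional assay on HepG2 cells (Homo sapiens) for antiproliferative activity, read by MTT assay, with a stated time of 72 h (a lower number here means a stronger inhibitor, a higher number a weaker inhibitor), compound 1 gives only a limit, > 100000 nM, as stated in the limit of > 100000 nM in this assay, at which 1 of the 3 values shown sits. In this assay compound 2 gives 67900 nM. In this assay compound 3 gives 61800 nM, and compound 3 and compound 2 sit within the scatter of each other, as a 1.1-fold lower number from compound 2 to compound 3 (0.04 log units; within the scatter) shows. Compound 1 contributes only its limit.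

Compound 4 `COc1cc2c(Nc3ccc(C#N)cc3)ncnc2cc1OCCCN1CCc2ccccc2C1` has not yet been measured. It differs from compound 3 by 1,2,3,4-tetrahydroisoquinolin-2-yl in place of 4-(hydroxymethyl)piperidin-1-yl on a saturated chain carbon, three bonds along the chain from an oxygen on an aromatic ring. The measured steps that bear on this change are the exchanges of the amine on the chain: an at least 1.4-fold lower number from compound 1 to compound 2 (0.16 log units; that floor lies within the scatter), an at least 1.6-fold lower number from compound 1 to compound 3 (0.20 log units; that floor lies within the scatter), and a 1.1-fold lower number from compound 2 to compound 3 (0.04 log units; within the scatter), none of which goes beyond the scatter. Replacing one cyclic amine on that chain with another is therefore expected to give no step beyond the scatter in this assay, and the estimated step is a 1.2-fold lower number from compound 3 to compound 4 (0.09 log units; within the scatter). The number for compound 4 is estimated at 50000 nM, within a range from 15000 nM to 150000 nM.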

Compound 4, half-maximal inhibitory concentration: > 100000 nM
Compound 4: only a limit was reported (the forecaster's own chance of this, stated with the estimate: 35%); middle value at least 2.0-fold (0.30 log units) from the limit.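

In this assay compound 4 gives only a limit, the same one as compound 1: the limit of > 100000 nM in this assay, at which 2 of the 4 values shown sit. Setting 1,2,3,4-tetrahydroisoquinolin-2-yl on this chain carbon gives an at least 1.6-fold higher number from compound 3 to compound 4 (0.20 log units; that floor lies within the scatter) and an at least 1.4-fold higher number from compound 2 to compound 4 (0.16 log units; that floor lies within the scatter), while the step between the two limits cannot be read; both readable steps are floors, so their true size remains unknown. Even so, the earlier compounds left open whether any cyclic amine here would give a number, and among these four only the amines carrying hydroxy or hydroxymethyl do so, with no compound going against this.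

From the compounds shown here alone, it remains open whether this goes with the hydroxy group or with the piperidine ring itself. Going by these compounds, a plain piperidine or a morpholine on the same propyl chain would separate the two, and the effect of a shorter or longer chain also stays open.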